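Swapping the chlorophenyl of compound 2 for a furan ring

The source may hold more compounds than are shown below. What is called first, only, known or untested is meant among the compounds shown, and "the series" means these compounds.

Compound 1 `CC1=CC[C@H](C(C)(C)NC(=S)N/N=C/c2ccccc2Cl)CC1`: 64500 nM
Compound 2 `CC1=CC[C@H](C(C)(C)NC(=S)N/N=C/c2cccc(Cl)c2)CC1`: 1400 nM

Both compounds were tested in a functional assay on NCI-H460 cells (Homo sapiens) for inhibition, read by sulforhodamine B assay, with a stated time of 48 h; a higher number here means a weaker inhibitor of growth, a lower number a stronger inhibitor of growth. Within the data shown here, of the two, compound 2 stands lowest, and its only neighbour, compound 1, lies well apart: the step of a 46-fold lower number from compound 1 to compound 2 (1.66 log units; beyond the scatter) is large and far beyond the scatter, showing that the aromatic group hanging on the carbon with a double bond to nitrogen governs the number strongly.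

Compound 3 `CC1=CC[C@H](C(C)(C)NC(=S)N/N=C/c2ccco2)CC1` takes this further with furan-2-yl in place of 3-chlorophenyl on a carbon with a double bond to nitrogen. Among the measured compounds shown here, no measured step covers this kind of exchange; the only step on record concerns a chlorophenyl group alone, so it tells that this position matters, not in which direction a furan ring will push. The absence of any furan-bearing comparison leaves a wide range. Because the step of a 46-fold lower number from compound 1 to compound 2 (1.66 log units; beyond the scatter) found compound 2 at the favourable end of what has been seen, the estimate for compound 3 is placed somewhat higher, as a cautious guess. In this assay compound 3 is expected to give 6000 nM, between 1000 nM and 40000 nM. The expected step is a 4.3-fold higher number from compound 2 to compound 3 (0.63 log units; beyond the scatter).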

Compound 3, concentration for 50% growth inhibition: 13500 nM
Compound 3: middle estimate off by 2.3-fold (0.35 log units), on the low side; the measured number falls inside the stated range.
By their numbers in this assay, from the lowest: compound 2; then compound 3; then compound 1.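

In this assay, the result shows that the group on the carbon with a double bond to nitrogen need not be a chlorophenyl ring for growth inhibition to remain, since furan-2-yl gives a usable number, though a poorer one than 3-chlorophenyl (a 9.6-fold higher number from compound 2 to compound 3 (0.98 log units; beyond the scatter)). The same exchange made against 2-chlorophenyl runs the other way (a 4.8-fold lower number from compound 1 to compound 3 (0.68 log units; beyond the scatter)), so the effect of moving to furan-2-yl depends on which chlorophenyl ring it replaces, and the three groups now rank in a clear order, with 3-chlorophenyl best and 2-chlorophenyl worst. The change removes the chlorine, shrinks the ring and adds a hydrogen-bond acceptor all at once, and nothing at hand separates these differences or explains the order.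

A plain phenyl ring with no chlorine would show how much of the gap belongs to the chlorine itself, and a thiophene ring would show whether the furan oxygen matters. From the compounds shown here alone, how a phenyl ring carrying an amine or a carboxylic acid at that same place would compare also remains open.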